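A few compounds are considered here, and "the series" means these few. Any claim that something is new, unique, unknown or untested is made for them only; others in the source may bear on it.

Among the compounds with values here, compound 1 `COc1cc(C)cc(-c2nn(CC#N)cc2-c2ccc(-c3cccc(C(C)=O)c3)nc2)c1` and compound 2 `Cc1cc(O)cc(-c2nn(CC#N)cc2-c2ccnc(-c3ccc(Oc4ccccc4)cc3)c2)c1` share one core and differ in several places at once, so no single step between them can be drawn. In a functional assay on MOLT-4 cells (Homo sapiens) for inhibition, read by sulforhodamine B assay, with a stated time of 48 h (a higher number here means a weaker inhibitor of growth, a lower number a stronger inhibitor of growth), compound 1 gives 3350 nM. In this assay compound 2 gives 2030 nM; the two numbers lie within the scatter of each other, so nothing separates compound 2 from compound 1 on the numbers shown. Compound 3 `Cc1cc(O)cc(-c2nn(CC#N)cc2-c2ccnc(-c3ccc(N(C)C)cc3)c2)c1` has not been measured. Its change from compound 2 is dimethylamino in place of phenoxy on an aromatic carbon. Nothing in the measured pair speaks to this kind of change. The step from compound 2 to compound 3 is therefore expected to be small, with a mild lean toward a higher number, a 1.5-fold higher number from compound 2 to compound 3 (0.17 log units; within the scatter). For compound 3 the estimate in this assay is 3000 nM, with a range from 800 nM to 11000 nM.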

Compound 3, concentration for 50% growth inhibition: 3170 nM
For compound 3 the middle estimate is 1.1-fold (0.02 log units) below the measured one; the measured number falls inside the stated range.
By their numbers in this assay, from the lowest: compounds 2, 3 and 1 (each within the scatter of the next).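

Within the data shown here, this is the first step in the account that can be read in one place: dimethylamino in place of phenoxy on an aromatic carbon of a six-membered aromatic ring of carbon only, para to a large group. In this assay the change gives a 1.6-fold higher number from compound 2 to compound 3 (0.19 log units; within the scatter), so a group of 7 heavy atoms with a ring and a group of 3 heavy atoms with no ring are not told apart at this position. No measured evidence bears on this result.

The compounds shown leave open whether other groups at this position, such as a carboxylic acid, a methoxy group or a morpholine ring, would also stay within the scatter of compound 2. They also leave open whether a longer chain on the amine nitrogen would do the same.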